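The source may report more compounds than this note shows. Statements on the series, on what has been measured and on what is new or still open speak of the compounds shown alone.

Measured so far:
compound 1 `N#Cc1cc2c(nc1N1CCC(C(=O)NS(=O)(=O)Cc3cc(Cl)cc(Cl)c3)CC1)COC2=O` gives 30500 nM
compound 2 `N#Cc1cc2c(nc1N1CC(C(=O)NS(=O)(=O)Cc3ccccc3)C1)COC2=O` gives > 300000 nM (a limit of the assay)

For the measured compounds named here, in a functional assay (Platelet, plasma) for inhibition, with Homo sapiens as the target (on this read-out lower numbers stand for stronger inhibition and higher numbers for weaker inhibition), compound 1 gives 30500 nM as the only actual number in this small set. For compound 2 the reading of > 300000 nM is a limit and not a number.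

Compound 3 `N#Cc1cc2c(nc1N1CCC(C(=O)NS(=O)(=O)Cc3ccc(F)cc3F)CC1)COC2=O` keeps the core of compound 1 and has 2,4-difluorophenyl in place of 3,5-dichlorophenyl on a saturated chain carbon bound to a sulfonyl sulfur. The counted difference is 2,4-difluorophenyl in place of 3,5-dichlorophenyl on a saturated chain carbon bound to a sulfonyl sulfur and nothing else changes. Going by the values given here, no measured pair shows a swap of this kind, so the expectation in this assay starts from compound 1 at 30500 nM and remains loose. A modest weakening is expected, with the estimated step of a 1.8-fold higher number from compound 1 to compound 3 (0.26 log units; within the scatter) as its size. Compound 3 is estimated at 55000 nM in this assay, with an expected range of 15000 nM to 200000 nM around that figure.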

Compound 3, half-maximal inhibitory concentration: 5200 nM
For compound 3 the middle estimate is 11-fold (1.02 log units) above the measured one, outside the stated range (below it).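

In this assay, 2,4-difluorophenyl in place of 3,5-dichlorophenyl on a saturated chain carbon bound to a sulfonyl sulfur gives a 5.9-fold lower number from compound 1 to compound 3 (0.77 log units; beyond the scatter) and thus stronger inhibition. This is the only pair shown that differs in one place, and it shows that this position responds to a change in the phenyl substituents alone, with the heavy-atom, hydrogen-bond donor and acceptor counts and the net charge of the group all unchanged. Nothing shown gives a cause for this step.

As far as these compounds go, whether a 2,4-dichlorophenyl or a 3,5-difluorophenyl group at this place would read closer to compound 1 or to compound 3 remains open. So does the reading of an unsubstituted phenyl group on the core of compound 1.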